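Compound 1 to compound 4: a piperidine swap on the chain

The source may hold more compounds than are shown below. What is called first, only, known or untested is meant among the compounds shown, and "the series" means these compounds.

- compound 1 `CN(C)CCCCCn1c2c(c3ccccc31)C(=O)c1c[n+]([O-])c3ccccc3c1C2=O` gives 210 nM
- compound 2 `O=C1c2c[n+]([O-])c3ccccc3c2C(=O)c2c1c1ccccc1n2Cc1cn(C[C@H](O)CO)nn1` gives 1030 nM
- compound 3 `O=C1c2c[n+]([O-])c3ccccc3c2C(=O)c2c1c1ccccc1n2CCCCN1CCNCC1` gives 540 nM

In a functional assay on A549 cells (Homo sapiens) for cytotoxicity, read by MTT assay, with a stated time of 72 h (a lower number here means a stronger inhibitor, a higher number a weaker inhibitor), compound 1 has the lowest of the three numbers, and both steps away from it lie beyond the scatter. The change to compound 4 `O=C1c2c[n+]([O-])c3ccccc3c2C(=O)c2c1c1ccccc1n2CCCCN1CCCCC1` is piperidin-1-yl in place of (dimethylamino)methyl on a saturated chain carbon, four bonds along the chain from an aromatic nitrogen on a saturated chain carbon, four bonds along the chain from an aromatic nitrogen.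

Among the compounds with values here, compound 3 is the closest precedent, carrying piperazin-1-yl at the same place, and its step is a 2.6-fold higher number from compound 1 to compound 3 (0.41 log units; beyond the scatter) in this assay for that replacement. Compound 2 is a more remote precedent, with 1-(2,3-dihydroxypropyl)-1H-1,2,3-triazol-4-yl entering, and its step is a 4.9-fold higher number from compound 1 to compound 2 (0.69 log units; beyond the scatter) in the same read-out. Both steps go upward, but neither carries piperidin-1-yl itself.

A small upward step is therefore expected, estimated as a 1.7-fold higher number from compound 1 to compound 4 (0.22 log units; within the scatter) in this assay with real uncertainty. For compound 4 the expected value is 350 nM with an estimated range from 130 nM to 900 nM in this assay as the measure.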

Compound 4, half-maximal inhibitory concentration: 150 nM
For compound 4 the middle estimate is 2.3-fold (0.37 log units) above the measured one, and the stated range covers the measured number.
By their numbers in this assay, from the lowest: compounds 4 and 1 (each within the scatter of the next); then compounds 3 and 2 (each within the scatter of the next).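

In this assay, a ring at the chain end proved compatible with the activity of compound 1, since the step with piperidin-1-yl, a 1.4-fold lower number from compound 1 to compound 4 (0.15 log units; within the scatter), stays within the scatter, unlike the two earlier steps away from compound 1. The same position also separates two rings, as piperidin-1-yl in place of piperazin-1-yl gives a 3.6-fold lower number from compound 3 to compound 4 (0.56 log units; beyond the scatter), while the wider replacement of the triazole-bearing side chain by 3-(piperidin-1-yl)propyl gives a 6.9-fold lower number from compound 2 to compound 4 (0.84 log units; beyond the scatter). No evidence is available that would explain these differences.

As far as these compounds go, it remains open whether a morpholine ring or a primary amine at the chain end would stay level with compound 1 and compound 4 or fall nearer compound 3. From the compounds shown here alone, the effect of a longer chain carrying the piperidine ring also remains open.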